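The source may hold more compounds than are shown below. What is called first, only, known or untested is meant among the compounds shown, and "the series" means these compounds.

Measured compounds in an ADME assay on CCRF-CEM cells (Homo sapiens) for cytotoxicity, read by trypan blue exclusion, with a stated time of 6 days; on this read-out lower numbers stand for higher toxicity in this test and higher numbers for lower toxicity in this test:

- compound 1, `C=C(OCC)c1nc(N)nc2c1ncn2[C@@H]1O[C@H](CO)[C@@H](O)[C@@]1(C)O`: in this assay compound 1 gives > 100000 nM, a limit of the test.
- compound 2, `C[C@@]1(O)[C@H](O)[C@@H](CO)O[C@H]1n1cnc2c(N)nc(N=[N+]=[N-])nc21`: in this assay compound 2 gives > 100000 nM, likewise a limit.
- compound 3, `C[C@@]1(O)[C@H](O)[C@@H](CO)O[C@H]1n1cnc2c(N)nc(ONC(=O)OCc3ccccc3)nc21`: in this assay compound 3 gives > 100000 nM, again a limit.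

Compound 2 therefore stands nowhere in particular on a scale of numbers: its value is a limit, and so are the two other values shown, all sitting at the limit of > 100000 nM in this assay, at which 3 of the 3 values shown sit. Among the compounds with values here, no step between measured compounds can be drawn from this set, since no pair gives two numbers.

Compound 4, `CONc1nc(N)c2ncn([C@@H]3O[C@H](CO)[C@@H](O)[C@@]3(C)O)c2n1`, differs from compound 2 by methoxyamino in place of azido on an aromatic carbon. Three substituents at this position of the shared core have so far left the cytotoxicity read-out at the limit, and nothing among them points to a direction for the change to methoxyamino. The expected step that the limit leaves unreadable from compound 2 to compound 4 is therefore none beyond the scatter, and compound 4 is estimated at 150000 nM, with a range from 50000 nM to 500000 nM, most probably reported again only as a limit.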

Compound 4, half-maximal cytotoxic concentration: > 100000 nM
Compound 4: only a limit was reported (the forecaster's own chance of this, stated with the estimate: 85%); the middle value is on the limit's open side.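

No step can be read from compound 2 to compound 4 in this assay, since both values are limits: the limit of > 100000 nM in this assay, at which 4 of the 4 values shown sit.

The compounds shown leave open whether any group on this aromatic carbon of the shared core gives a readable value in this assay, and how methoxyamino compares with azido there.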